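The source may report more compounds than this note shows. Statements on the series, on what has been measured and on what is new or still open speak of the compounds shown alone.

Measured so far in this assay:
compound 1 `COc1cc(N)c(Cl)cc1C(=O)CCC1CCN(CCNS(=O)(=O)c2ccc3c(c2)NC(=O)CO3)CC1`: 40%
compound 2 `COc1ccc(S(=O)(=O)N2CCC(CCC(=O)c3cc(Cl)c(N)cc3OC)CC2)cc1`: "not active" (no number reported)

In an assay on HEK293 cells for displacement of a labelled ligand from 5-hydroxytryptamine receptor 6 (Homo sapiens), with a stated time of 60 min, tested at 1 uM, in the presence of a further agent that is not named here (a lower number here means a weaker effect, a higher number a stronger effect of the compound at the concentration tested), compound 1 gives 40%. Within the data shown here, this is the only number in the set, so compound 1 stands alone as the reference point; compound 2 is reported in this assay only as "not active" (no number reported), with no number attached, and no step between measured compounds is available.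

Compound 3 `COc1ccc(S(=O)(=O)NCCN2CCC(CCC(=O)c3cc(Cl)c(N)cc3OC)CC2)cc1` keeps the core of compound 1 and differs from it by a group of 8 heavy atoms (7 carbon, 1 oxygen; one six-membered aromatic ring of carbon only) in place of a group of 11 heavy atoms (8 carbon, 1 nitrogen, 2 oxygen; one six-membered non-aromatic ring with 2 hetero atoms, one six-membered aromatic ring of carbon only), on a sulfonyl sulfur. Among the measured compounds shown here, compound 2 also bears a 4-methoxyphenyl on its sulfonyl sulfur and is reported as "not active" (no number reported), which is the only guide to this change.

For compound 3 a downward step beyond the scatter is expected, a number 25 percentage points lower from compound 1 to compound 3 (beyond the scatter), with the possibility that the assay again reports only "not active". The estimate for compound 3 is 15%, within a range from 0% to 40%.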

Compound 3, a percentage reported as inhibition, at one concentration (the size of the read-out at that concentration, not a potency): 52%
For compound 3 the middle estimate is 37 percentage points below the measured one, and the stated range ends below it.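

In this assay, replacing the group of compound 1 with a 4-methoxyphenyl on a sulfonyl sulfur whose other neighbour is a sulfonamide nitrogen gives a number 12 percentage points higher from compound 1 to compound 3 (beyond the scatter), so the larger group with its six-membered non-aromatic ring is not required for the read-out at this position. Compound 2 bears the same 4-methoxyphenyl and is reported as "not active" (no number reported), whereas compound 3 gives 52%, so the 4-methoxyphenyl alone does not account for the result of compound 2; the two differ in how the sulfonyl group is attached to the rest of the molecule. No supporting evidence bears on why the read-out changes at this position.

The compounds shown leave open whether the methoxy group itself contributes, as a plain phenyl or a 4-chlorophenyl on the same sulfonyl sulfur would show. They also leave open how a longer chain on the sulfonamide nitrogen would read in this assay.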